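From compound 3 to compound 4: a longer chain

This account rests on a few compounds, and the source may have more. Where it says the series, first, only, none or still open, it means among the compounds named here.

In a functional assay for inhibition, read by fluorescence and spectrophotometry, with a stated time of 30 h (on this read-out lower numbers stand for stronger inhibition and higher numbers for weaker inhibition), compound 1 (`COc1ccc(-c2cc(=O)c3ccc(O)cc3o2)cc1OC`) gives 47400 nM, compound 2 (`COc1cc(-c2cc(=O)c3ccc(O)cc3o2)cc(OC)c1OC`) gives 51400 nM and compound 3 (`COc1ccc(-c2cc(=O)c3ccc(OCCCN4CCC(C)CC4)cc3o2)cc1`) gives 42600 nM. Compound 3 therefore stands level with the other two: its gaps to both lie within the scatter, so these numbers set no order among the three.

Compound 4 (`COc1ccc(-c2cc(=O)c3ccc(OCCCCN4CCC(C)CC4)cc3o2)cc1`) has not yet been measured. Its difference from compound 3 is (4-methylpiperidin-1-yl)methyl in place of 4-methylpiperidin-1-yl on a saturated chain carbon, three bonds along the chain from an oxygen on an aromatic ring. Cut one bond further out, the same difference reads 2-(4-methylpiperidin-1-yl)ethyl to 3-(4-methylpiperidin-1-yl)propyl.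

For the measured compounds named here, only one measured step is available, a 1.1-fold higher number from compound 1 to compound 2 (0.04 log units; within the scatter), and it is a different change: methoxy in place of hydrogen on an aromatic carbon. It bears on the question only as a sign of how flat the series has been so far. Going by the values given here, no measured pair varies the chain, so the data give no direct guide to this change. With compound 3 at 42600 nM as the starting point, no shift beyond the scatter is expected in this assay, and neither direction is favoured. The expected step is a 1.2-fold lower number from compound 3 to compound 4 (0.07 log units; within the scatter). The estimate for compound 4 is 36000 nM, with an expected range of 17000 nM to 70000 nM.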

Compound 4, half-maximal inhibitory concentration: 48200 nM
Compound 4: middle estimate off by 1.3-fold (0.13 log units), on the low side; the range from low to high includes it.
By their numbers in this assay, from the lowest: compounds 3, 1, 4 and 2 (each within the scatter of the next).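

In this assay, for the compounds shown here, the change from 2-(4-methylpiperidin-1-yl)ethyl to 3-(4-methylpiperidin-1-yl)propyl gives a 1.1-fold higher number from compound 3 to compound 4 (0.05 log units; within the scatter), the first measured step that varies the chain, at a saturated chain carbon three bonds along the chain from an oxygen on an aromatic ring. This lengthening therefore leaves the read-out within the scatter with the six-membered non-aromatic ring unchanged, so the flatness seen so far now covers a change in the chain as well as the aromatic methoxy change in a 1.1-fold higher number from compound 1 to compound 2 (0.04 log units; within the scatter). No measurement shown here bears on why the chain change leaves the number within the scatter.

Still open, going by these compounds, is whether a chain longer than the 3-(4-methylpiperidin-1-yl)propyl group, or a morpholine or dimethylamino group in place of the 4-methylpiperidine, would move the number beyond the scatter in this assay. Also open, on these data alone, is whether the same lengthening would read the same on a core carrying the methoxy groups of compound 2.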